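Indole for tolyl on the ring amide nitrogen

The compounds below may be only part of what the source reports. "The series", "measured", "known", "first", "only" and "open" are said of these compounds alone.

Measured compounds:
compound 1 `CO[C@@H]1CC=C2NN(c3ccccn3)C(=O)CC[C@]2(c2ccccc2)O1`, 1400 nM
compound 2 `CO[C@@H]1CC=C2N(c3ccc(C)cc3)C(=O)C[C@]2(c2ccccc2)O1`, 4300 nM

Of the compounds shown here, two have been measured in a functional assay on HCT-116 cells (Homo sapiens) for cytotoxicity, read by sulforhodamine B assay, with a stated time of 48 h; a higher number here means a weaker inhibitor, a lower number a stronger inhibitor. Compound 1 gives 1400 nM. Compound 2 gives 4300 nM, the higher of the two numbers, and its gap to compound 1 lies beyond the scatter; compound 2 is therefore the weaker of the pair in this assay. Going by the values given here, the two cores differ in more than one place, so no single step connects them.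

Compound 3 `CO[C@@H]1CC=C2N(c3c[nH]c4ccccc34)C(=O)C[C@]2(c2ccccc2)O1` is the next compound. It differs from compound 2 by 1H-indol-3-yl in place of 4-methylphenyl on an amide-type nitrogen in a ring. Nothing measured in this series shows what such a swap does on this nitrogen, so the expectation rests on compound 2 alone. A step within the scatter in either direction is expected, with a slight lean toward a lower number, since the group that enters is larger and carries a hydrogen-bond donor. For compound 3 the expected step from compound 2 is a 1.4-fold lower number from compound 2 to compound 3 (0.16 log units; within the scatter), and the estimate for compound 3 in this assay is 3000 nM, between 1000 nM and 9000 nM.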

Compound 3, half-maximal inhibitory concentration: 7130 nM
Beside the measured number, compound 3's estimate is 2.4-fold (0.38 log units) below it; the range from low to high includes it.
By their numbers in this assay, from the lowest: compound 1; then compounds 2 and 3 (each within the scatter of the next).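

In this assay, 1H-indol-3-yl in place of 4-methylphenyl on the amide-type nitrogen in a ring gives a 1.7-fold higher number from compound 2 to compound 3 (0.22 log units; within the scatter), so the two groups cannot be told apart at this position. Going by these compounds alone, this pair gives the first reading on this nitrogen: the entering group brings a five-membered aromatic ring with 1 hetero atom and a hydrogen-bond donor, yet the two numbers stay within the scatter of each other. No accompanying data bear on this result.

The compounds shown leave open whether the hydrogen-bond donor of the indole matters at all, which 1-methylindol-3-yl would address. They also leave open whether this nitrogen accepts a group without an aromatic ring, such as a simple alkyl chain or a chain ending in an amine.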